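Trimethoxyphenyl Ether Variant of an Isoxazole Piperazine Series

A few compounds are considered here, and "the series" means these few. Any claim that something is new, unique, unknown or untested is made for them only; others in the source may bear on it.

Measured so far:
- compound 1 `FC(F)(F)c1ccc(CN2CCN(Cc3cc(-c4ccc(OCc5ccccc5Cl)cc4)on3)CC2)cc1` gives 2800 nM
- compound 2 `COc1ccc(COc2ccc(-c3cc(CN4CCN(Cc5ccc(C(F)(F)F)cc5)CC4)no3)cc2)cc1` gives 1300 nM

Both numbers come from a functional assay on MCF7 cells (Homo sapiens) for antiproliferative activity, read by sulforhodamine B assay, with a stated time of 72 h; on this read-out lower numbers stand for stronger inhibition and higher numbers for weaker inhibition. Compound 1 carries a 2-chlorophenyl on a saturated chain carbon bound to an oxygen on an aromatic ring, and within this pair it stands at the highest number, so it is the weaker of the two. Within the data shown here, the only neighbouring change known is a 2.2-fold lower number from compound 1 to compound 2 (0.33 log units; beyond the scatter), where 4-methoxyphenyl replaced 2-chlorophenyl at that position.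

Compound 3 `COc1cc(COc2ccc(-c3cc(CN4CCN(Cc5ccc(C(F)(F)F)cc5)CC4)no3)cc2)cc(OC)c1OC` takes the same route one step further: 3,4,5-trimethoxyphenyl in place of 2-chlorophenyl on a saturated chain carbon bound to an oxygen on an aromatic ring. Among the measured compounds shown here, no measured pair covers the move from 4-methoxyphenyl to 3,4,5-trimethoxyphenyl, so the single step from compound 1 to compound 2 is the only guide. That step was modest and pointed to a lower number, and a phenyl bearing methoxy groups in place of 2-chlorophenyl is again what compound 3 brings. A lower number than compound 1 is therefore expected, most likely of a size close to the step already seen, which would place compound 3 near compound 2; the expected step is a 1.9-fold lower number from compound 1 to compound 3 (0.27 log units; within the scatter). For compound 3 the estimated value in this assay is 1500 nM, with a likely range from 500 nM to 4500 nM.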

Compound 3, half-maximal inhibitory concentration: 1800 nM
The estimate for compound 3 lay 1.2-fold (0.08 log units) below the measured number; the measured number falls inside the stated range.
By their numbers in this assay, from the lowest: compounds 2, 3 and 1 (each within the scatter of the next, the first and the last beyond it).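

In this assay, the place on a saturated chain carbon bound to an oxygen on an aromatic ring accepts 3,4,5-trimethoxyphenyl, with 12 heavy atoms and 3 hydrogen-bond acceptors against 7 heavy atoms and 0 acceptors in 2-chlorophenyl, yet the result, a 1.6-fold lower number from compound 1 to compound 3 (0.19 log units; within the scatter), lies within the scatter, so compound 3 cannot be told apart from compound 1. It cannot be told apart from the 4-methoxyphenyl compound either, since a 1.4-fold higher number from compound 2 to compound 3 (0.14 log units; within the scatter), also lies within the scatter, which means that the additional methoxy groups of compound 3 bring no gain that can be read here, and only compounds 1 and 2 remain separated by more than the scatter. No measurement at hand explains these numbers.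

The compounds shown leave open how a plain phenyl, or a phenyl carrying an amine or a carboxylic acid, would behave at this same place. They also leave open whether a single methoxy group on a different ring carbon, or a longer chain leading to the ring, would give a number clearly set apart from those seen so far.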